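Halo versus nitro on the indole core: a single exchange

A few compounds are considered here, and "the series" means these few. Any claim that something is new, unique, unknown or untested is made for them only; others in the source may bear on it.

Compound 1 `O=C(Cc1cccnc1)c1cc2cc(F)ccc2[nH]1` gives 24% in an in vitro assay on P815B cells for inhibition of Indoleamine 2,3-dioxygenase 1 (Mus musculus), tested at 20 uM; a lower number here means less inhibition, a higher number more inhibition at the concentration tested (going by the name of the read-out). Compound 2 `O=C(Cc1cccnc1)c1cc2cc([N+](=O)[O-])ccc2[nH]1` is reported in this assay only as "not active" (no number reported), with no number attached, so it stands on no value of its own and its position relative to compound 1 cannot be sized. Compound 3 `O=C(Cc1cccnc1)c1cc2cc(Br)ccc2[nH]1` differs from compound 2 by bromo in place of nitro on an aromatic carbon. Since compound 2 gave no measurable inhibition, the step to compound 3 is expected to run upward in this assay, toward the level of compound 1, though its size is uncertain. Compound 3 is estimated at 25%, within 5% to 50%.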

Compound 3, a percentage reported as inhibition, at one concentration (the size of the read-out at that concentration, not a potency): "not active" (no number reported)
The entry for compound 3 holds no number; no gap can be computed for the estimate.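

Compound 2 and compound 3 are both reported in this assay only as "not active", so no step can be read between them. The compounds shown leave open how far nitro and bromo each lie from the fluoro of compound 1. No evidence bears on this result.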